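This account rests on a few compounds, and the source may have more. Where it says the series, first, only, none or still open, it means among the compounds named here.

Among the measured compounds shown here, compound 2 `O=C(COc1ccc2cc(/C=C3/SC(=O)NC3=O)ccc2c1)Nc1ccccc1` gives 2100 nM in an assay on isolated protein for inhibition of histone deacetylase 4 (Homo sapiens), with a stated time of 1 h (a higher number here means a weaker inhibitor, a lower number a stronger inhibitor), the higher of the two numbers so far, although the step of a 1.2-fold higher number from compound 1 to compound 2 (0.09 log units; within the scatter) lies within the scatter; compound 1 `Cc1ccc(NC(=O)COc2ccc3cc(/C=C4/SC(=O)NC4=O)ccc3c2)cc1` gives 1700 nM in this assay. Compound 3 `O=C(COc1ccc2cc(/C=C3/SC(=O)NC3=O)ccc2c1)Nc1ccc([N+](=O)[O-])cc1` differs from compound 2 by nitro in place of hydrogen on an aromatic carbon. For the measured compounds named here, the only measured step that bears on it is that same exchange on the six-membered aromatic ring of carbon only, and it moved nothing beyond the scatter, so no step beyond the scatter is expected in this assay. For compound 3 the estimate is 2000 nM, lying between 700 nM and 6000 nM. This amounts to an expected step of a 1.1-fold lower number from compound 2 to compound 3 (0.02 log units; within the scatter).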

Compound 3, half-maximal inhibitory concentration: 1700 nM
Estimate against measurement, compound 3: 1.2-fold (0.07 log units) above; the range from low to high includes it.
By their numbers in this assay, from the lowest: compounds 1, 3 and 2 (each within the scatter of the next).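

In this assay, putting nitro in place of hydrogen on the six-membered aromatic ring, para to a large group, gives a 1.2-fold lower number from compound 2 to compound 3 (0.09 log units; within the scatter), and putting it in place of methyl gives no change at the digits printed from compound 1 to compound 3 (within the scatter). Hydrogen, methyl and nitro therefore read alike here across compound 1, compound 2 and compound 3, and this position now holds a group of three heavy atoms with no step beyond the scatter. Nothing available explains this flat reading. On these data alone, whether an amine or a carboxylic acid at the same position would also read alike remains open. So does whether this holds for any change to the shared core.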